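Single benzyloxymethyl to benzyl swap on the shared core

This account rests on a few compounds, and the source may have more. Where it says the series, first, only, none or still open, it means among the compounds named here.

Working notes on a series of three measured compounds and one awaiting measurement.

In a functional assay on CCRF-CEM cells (Homo sapiens) for inhibition (on this read-out lower numbers stand for higher toxicity in this test and higher numbers for lower toxicity in this test), compound 3 `O=C1c2ccccc2N(COCc2ccccc2)S(=O)(=O)N1COCc1ccccc1` gives 27700 nM. Among the three measured compounds it stands second highest. Compound 1 `O=C1c2ccccc2N(Cc2ccc(Cl)cc2)S(=O)(=O)N1Cc1ccccc1` gives 19700 nM, within the scatter of compound 3, while compound 2 `O=C1c2ccccc2N(Cc2ccccc2)S(=O)(=O)N1Cc1ccccc1` gives 108000 nM, beyond the scatter above compound 3. Among the compounds with values here, the only single-place step available is a 5.5-fold higher number from compound 1 to compound 2 (0.74 log units; beyond the scatter); it concerns a chloro substituent and so does not bear directly on the step now under review.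

Compound 4 `O=C1c2ccccc2N(COCc2ccccc2)S(=O)(=O)N1Cc1ccccc1` differs from compound 3 in one place: phenyl in place of benzyloxy on a saturated chain carbon bound to an amide-type nitrogen in a ring. Compound 4 thereby carries one (benzyloxy)methyl group and one benzyl group on the core, and it sits between compound 3, with two (benzyloxy)methyl groups, and compound 2, with two benzyl groups. Within the data shown here, no step is given for that pair; compound 3 at 27700 nM lies below compound 2 at 108000 nM by more than the scatter. If each group swap contributes in like measure, compound 4 is expected to move about halfway, an expected step of a 1.9-fold higher number from compound 3 to compound 4 (0.27 log units; within the scatter) toward a higher number, a step that may or may not clear the scatter. Compound 4 is therefore estimated at 52000 nM, with a range from 22000 nM to 120000 nM.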

Compound 4, half-maximal cytotoxic concentration: 25000 nM
The estimate for compound 4 lay 2.1-fold (0.32 log units) above the measured number; the measured number falls inside the stated range.
By their numbers in this assay, from the lowest: compounds 1, 4 and 3 (each within the scatter of the next); then compound 2.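

In this assay, within the data shown here, the change of (benzyloxy)methyl to benzyl on a saturated chain carbon bound to an amide-type nitrogen in a ring gives a 1.1-fold lower number from compound 3 to compound 4 (0.04 log units; within the scatter) and so cannot be read as a change in toxicity in this test, which is the first direct reading at this place. On a saturated chain carbon bound to a sulfonamide nitrogen in a ring, the exchanges read differently: benzyloxy in place of phenyl gives a 4.3-fold lower number from compound 2 to compound 4 (0.64 log units; beyond the scatter) and clears the scatter, while benzyloxy in place of 4-chlorophenyl gives a 1.3-fold higher number from compound 1 to compound 4 (0.10 log units; within the scatter) and does not, so within these compounds the two places do not respond alike to this exchange. No measurement at hand explains these steps.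

As far as these compounds go, whether the amide-type place stays as flat with a different kind of group, such as an amine or a carboxylic acid at the end of the chain, or a longer chain such as 2-phenylethyl, remains open. Also open, from the compounds shown here alone, is whether a 4-chlorobenzyl group at the amide-type place would give a step like the one seen at the sulfonamide place.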